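The source may report more compounds than this note shows. Statements on the series, on what has been measured and on what is new or still open speak of the compounds shown alone.

Measured compounds:
compound 1 `Cc1ccccc1-n1nc(C)c2c1NC(=O)[C@H](C)S[C@@H]2c1ccc(-c2cc3ccccc3o2)cc1`: 1500 nM
compound 2 `Cc1ccccc1-n1nc(C)c2c1NC(=O)[C@H](C)S[C@@H]2c1ccc(Oc2cccc(C(=O)O)c2)cc1`: "not active" (no number reported)
compound 3 `Cc1ccccc1-n1nc(C)c2c1NC(=O)[C@H](C)S[C@@H]2c1ccc(Oc2ccc(C(=O)O)cc2)cc1`: "not active" (no number reported)

In an assay on isolated protein for agonist activity at Bile acid receptor (Homo sapiens), read by AlphaScreen, with a stated time of 30 min (a lower number here means that less compound is needed, a higher number that more compound is needed for the effect), compound 1 gives 1500 nM. Compound 2 gives "not active" (no number reported) and compound 3 gives "not active" (no number reported), so neither returned a number, and compound 3 cannot be placed on a scale against compound 1. Compound 4 `Cc1ccccc1-n1nc(C)c2c1NC(=O)[C@H](C)S[C@@H]2c1ccc(-c2ccccc2)cc1` differs from compound 3 in one place: phenyl in place of 4-carboxyphenoxy on an aromatic carbon. Among the compounds with values here, no measured step with numbers is known for this change, so its size can only be guessed. Compound 1, which carries a different aromatic group rather than a carboxyphenoxy and gives 1500 nM, suggests that compound 4 may return a measurable value, a move toward activity, though the uncertainty is wide. Compound 4 is expected to give about 3000 nM, within the range 800 nM to 15000 nM.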

Compound 4, half-maximal effective concentration: 990 nM
For compound 4 the middle estimate is 3.0-fold (0.48 log units) above the measured one; low and high end bracket the measured number.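

At this position, phenyl and 1-benzofuran-2-yl cannot be told apart in this assay, with a 1.5-fold lower number from compound 1 to compound 4 (0.18 log units; within the scatter). Compound 3, carrying 4-carboxyphenoxy, is reported as not active, while compound 4, carrying phenyl, gives 990 nM, so this change yields a readable number, although the size of the step cannot be read. Nothing available explains these results.

Still open, as far as these compounds go, is whether the carboxylic acid or the ether oxygen separates compound 3 from compound 4; a plain phenoxy group here would address that. From the compounds shown here alone, how an amine at this position would behave also remains open.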